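Aryl swap on the piperazine amide of compound 3

The source may report more compounds than this note shows. Statements on the series, on what has been measured and on what is new or still open speak of the compounds shown alone.

Compound 1 `Cc1cccc(Cn2c(CN3CCN(C(=O)c4cccnc4)CC3)nc3ccccc32)c1` gives 24.5% in an assay on isolated protein for inhibition of aldehyde dehydrogenase 1A1 (Homo sapiens), read by spectrophotometry, tested at 10 uM; a lower number here means less inhibition, a higher number more inhibition at the concentration tested (going by the name of the read-out). Compound 2 `CC(=O)N1CCN(Cc2nc3ccccc3n2Cc2cccc(C)c2)CC1` gives 70.3%, and compound 3 `Cc1cccc(Cn2c(CN3CCN(C(=O)c4cccs4)CC3)nc3ccccc32)c1` gives 60.8%. Compound 3 thus stands second highest of the three numbers; its nearest neighbour is compound 2, and the two lie within the scatter of each other, while compound 1 sits well lower, the step of a number 36.3 percentage points higher from compound 1 to compound 3 (beyond the scatter) being large. The other large step in this set is a number 45.8 percentage points higher from compound 1 to compound 2 (beyond the scatter), whereas a number 9.5 percentage points lower from compound 2 to compound 3 (within the scatter) is within the scatter.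

Compound 4 `Cc1cccc(Cn2c(CN3CCN(C(=O)c4ccc(F)cc4)CC3)nc3ccccc32)c1` differs from compound 3 in one place: 4-fluorophenyl in place of thiophen-2-yl on a carbonyl carbon. Within the data shown here, no measured step exchanges one carbonyl-bound aryl for another carbon-only aromatic ring, so the bearing steps are only indirect: the two large steps leaving pyridin-3-yl, and the flat step between methyl and thiophen-2-yl. The expectation is therefore a step of a number 10.8 percentage points lower from compound 3 to compound 4 (beyond the scatter) of modest size, with a wide range. Compound 4 is estimated at 50%, expected to fall between 25% and 75%.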

Compound 4, a percentage reported as inhibition, at one concentration (the size of the read-out at that concentration, not a potency): 27.1%
Compound 4: middle estimate off by 22.9 percentage points, on the high side; the measured number falls inside the stated range.
By their numbers in this assay, from the lowest: compounds 1 and 4 (each within the scatter of the next); then compounds 3 and 2 (each within the scatter of the next).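

On the carbonyl carbon whose other neighbour is the amide-type nitrogen in a ring, an aromatic ring does not by itself preserve the number in this assay: 4-fluorophenyl in place of thiophen-2-yl gives a number 33.7 percentage points lower from compound 3 to compound 4 (beyond the scatter) here. 4-fluorophenyl in place of methyl gives a number 43.2 percentage points lower from compound 2 to compound 4 (beyond the scatter) and, in place of pyridin-3-yl, a number 2.6 percentage points higher from compound 1 to compound 4 (within the scatter) so the four compounds form two groups, with compounds 2 and 3 on one side and compounds 1 and 4 on the other. No measurement available here bears on what underlies this split.

The change from thiophen-2-yl to 4-fluorophenyl alters the ring and adds fluorine at once, so the compounds shown do not separate these two contributions. Plain phenyl, furan-2-yl or a propyl chain on the same carbonyl would test how far each group's numbers extend.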